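Series notes: amine substituent and ortho change on the benzamide

The source may report more compounds than this note shows. Statements on the series, on what has been measured and on what is new or still open speak of the compounds shown alone.

Measured so far in a functional assay on MKN-74 cells (Homo sapiens) for antiproliferative activity, with a stated time of 24 h; on this read-out higher numbers stand for weaker inhibition and lower numbers for stronger inhibition:
compound 1, `NC(=O)c1c(NC(=O)c2ccccc2F)sc2c1CCN(Cc1cccc(Cl)c1)C2`, gives 23300 nM
compound 2, `NC(=O)c1c(NC(=O)c2ccccc2F)sc2c1CCN(Cc1c(Cl)cccc1Cl)C2`, gives 7430 nM
compound 3, `NC(=O)c1c(NC(=O)c2ccccc2F)sc2c1CCN(C(=S)Nc1ccccc1Cl)C2`, gives 11100 nM

Compound 3 holds the second highest of the three numbers. Against compound 2 it sits within the scatter, and the step of a 2.1-fold lower number from compound 1 to compound 3 (0.32 log units; beyond the scatter) is the only one that separates it from another compound beyond the scatter. The two steps that pass beyond the scatter, a 3.1-fold lower number from compound 1 to compound 2 (0.50 log units; beyond the scatter) and a 2.1-fold lower number from compound 1 to compound 3 (0.32 log units; beyond the scatter), both change the group on the amine nitrogen in the ring; the step of a 1.5-fold higher number from compound 2 to compound 3 (0.17 log units; within the scatter) between the two larger groups stays within the scatter.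

Compound 4, `Cc1ccccc1C(=O)Nc1sc2c(c1C(N)=O)CCN(C(=S)Nc1ccccc1Cl)C2`, keeps the whole amine substituent of compound 3 and changes only the other end: methyl in place of fluoro on an aromatic carbon, ortho to a large group, which reads further out as 2-fluorophenyl to 2-methylphenyl. Among the compounds with values here, no measured step touches this position; every step so far varies the group on the amine nitrogen. There is therefore nothing that points to a shift in this assay in either direction, and the expectation is no step beyond the scatter.

Compound 4 is expected near compound 3, an estimated 11000 nM with a range from 4000 nM to 30000 nM, the expected step being a 1.0-fold lower number from compound 3 to compound 4 (0.00 log units; within the scatter).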

Compound 4, half-maximal inhibitory concentration: 11000 nM
Estimate against measurement, compound 4: no gap at the digits printed; low and high end bracket the measured number.
By their numbers in this assay, from the lowest: compounds 2, 4 and 3 (each within the scatter of the next); then compound 1.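

In this assay, the change of methyl in place of fluoro on an aromatic carbon, ortho to a large group, gives a 1.0-fold lower number from compound 3 to compound 4 (0.00 log units; within the scatter), so 2-fluorophenyl and 2-methylphenyl cannot be told apart with the amine substituent of compound 3 in place. Within the data shown here, this is the first reading at this end of the molecule, since all earlier steps varied the group on the amine nitrogen, and it shows that this particular exchange of one heavy atom for another leaves the read-out within the scatter. No measured evidence is available to explain this result.

Going by these compounds, the reading rests on a single pair, so it remains open whether 2-methylphenyl and 2-fluorophenyl would also match when paired with the chlorophenyl-bearing amine substituents of compound 1 and compound 2. Also open, on these data alone, is how this assay responds to other groups on the same aromatic carbon, such as methoxy, trifluoromethyl, an amine or a carboxylic acid, or to a benzoyl ring with hydrogen there in place of a substituent.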